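Methoxy for Hydrogen on the Shared Core

The source may hold more compounds than are shown below. What is called first, only, known or untested is meant among the compounds shown, and "the series" means these compounds.

Measured compounds:
compound 1 `Cc1nn(-c2ccccn2)c2cc(-c3ccc(CCC(=O)O)cc3)ccc12`, 1400 nM
compound 2 `O=C(O)CCc1ccc(-c2ccc3cnn(-c4ccccn4)c3c2)cc1`, 4500 nM

Within the data shown here, in a functional assay on cells for agonist activity at Free fatty acid receptor 1 (Mus musculus), read by FLIPR and calcium flux, with a stated time of 5 min (on this read-out higher numbers stand for an effect only at larger amounts of compound and lower numbers for an effect already at smaller amounts), compound 2 gives the highest of the two numbers known so far; its nearest neighbour is compound 1, and the step of a 3.2-fold higher number from compound 1 to compound 2 (0.51 log units; beyond the scatter) marks the gap between them. Compound 3 `COc1nn(-c2ccccn2)c2cc(-c3ccc(CCC(=O)O)cc3)ccc12` is not yet measured. Compound 3 differs from compound 2 as follows: methoxy in place of hydrogen on an aromatic carbon. Among the measured compounds shown here, the only measured step that bears on this change is the one from compound 1 to compound 2, in which a hydrogen took the place of a methyl at that same aromatic carbon and the number rose modestly, beyond the scatter. Putting a methoxy there instead of hydrogen is a substitution of comparable scale at the same carbon, so a modest move in the opposite direction, toward a lower number in this assay, is expected, though a result within the scatter cannot be excluded. Compound 3 is therefore estimated at 1800 nM, in a range from 700 nM to 5000 nM, which corresponds to an expected step of a 2.5-fold lower number from compound 2 to compound 3 (0.40 log units; beyond the scatter).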

Compound 3, half-maximal effective concentration: 2600 nM
For compound 3 the middle estimate is 1.4-fold (0.16 log units) below the measured one; measured number inside the range.
By their numbers in this assay, from the lowest: compounds 1, 3 and 2 (each within the scatter of the next, the first and the last beyond it).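

In this assay, the methoxy on this aromatic carbon gives a 1.7-fold lower number from compound 2 to compound 3 (0.24 log units; within the scatter), and replacing the methyl with it gives a 1.9-fold higher number from compound 1 to compound 3 (0.27 log units; within the scatter). Methoxy therefore cannot be told apart from either hydrogen or methyl at this carbon, although those two groups are separated by a 3.2-fold higher number from compound 1 to compound 2 (0.51 log units; beyond the scatter), so the three compounds do not form a clear order of groups at this position. Nothing available explains this outcome.

The compounds shown leave open whether a larger ether such as ethoxy, an amine or a chlorine atom on this same carbon would move the number beyond the scatter. They also leave open whether methoxy would behave the same way on a core with a different group in place of the pyridin-2-yl group.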